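Sulfonyl aryl change from compound 3 to compound 4

A few compounds are considered here, and "the series" means these few. Any claim that something is new, unique, unknown or untested is made for them only; others in the source may bear on it.

Compound 1 `COc1cc(N)c(Cl)cc1C(=O)CCC1CCN(CCNS(=O)(=O)c2ccc(N)cc2)CC1` carries a 4-aminophenyl on the sulfonyl sulfur; in an assay on brain for displacement of a labelled ligand from 5-hydroxytryptamine receptor 4 (Cavia porcellus), with a stated time of 30 min, in the presence of a further agent that is not named here (on this read-out lower numbers stand for stronger inhibition and higher numbers for weaker inhibition), compound 1 gives 1.97 nM. Compound 2 `COc1ccc(S(=O)(=O)N2CCC(CCC(=O)c3cc(Cl)c(N)cc3OC)CC2)cc1` in this assay has "not determined" (no result reported). Among the measured compounds shown here, compound 3 `COc1ccc(S(=O)(=O)NCCN2CCC(CCC(=O)c3cc(Cl)c(N)cc3OC)CC2)cc1Cl` carries a 3-chloro-4-methoxyphenyl on the sulfonyl sulfur; in this assay compound 3 gives 22.5 nM, the highest of the two numbers recorded, with compound 1 as its only measured neighbour. For the measured compounds named here, the one measured step at this position is an 11-fold higher number from compound 1 to compound 3 (1.06 log units; beyond the scatter).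

Compound 4 `COc1cc(N)c(Cl)cc1C(=O)CCC1CCN(CCNS(=O)(=O)c2ccc(C)cc2)CC1` differs from compound 3 in a single place: 4-methylphenyl in place of 3-chloro-4-methoxyphenyl on a sulfonyl sulfur. Going by the values given here, the 4-methylphenyl matches neither the 4-aminophenyl of compound 1 nor the 3-chloro-4-methoxyphenyl of compound 3, so no measured pair covers this change directly. Among the compounds with values here, the only step that bears on it, an 11-fold higher number from compound 1 to compound 3 (1.06 log units; beyond the scatter), shows that the aryl group on the sulfonyl sulfur can shift the read-out by a large amount, and the unsubstituted-looking 4-methylphenyl is taken to fall somewhere between the two measured aryl groups. For compound 4 the expected step in this assay is therefore a 2.8-fold lower number from compound 3 to compound 4 (0.45 log units; beyond the scatter), a move toward a lower number that is expected to pass the scatter but not to reach the level of compound 1. Compound 4 is estimated at 8 nM, with a range from 3 nM to 25 nM.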

Compound 4, inhibition constant: 18 nM
The estimate for compound 4 lay 2.3-fold (0.35 log units) below the measured number, and the stated range covers the measured number.
By their numbers in this assay, from the lowest: compound 1; then compounds 4 and 3 (each within the scatter of the next).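

Read in this assay, putting 4-methylphenyl in place of 3-chloro-4-methoxyphenyl on the sulfonyl sulfur gives a 1.3-fold lower number from compound 3 to compound 4 (0.10 log units; within the scatter), so the two aryl groups cannot be told apart on this read-out, even though they differ in heavy atoms and in hydrogen-bond acceptors. The new comparison with compound 1 isolates a single swap, methyl in place of amino on an aromatic carbon, and gives a 9.1-fold higher number from compound 1 to compound 4 (0.96 log units; beyond the scatter); together with an 11-fold higher number from compound 1 to compound 3 (1.06 log units; beyond the scatter), this leaves the 4-aminophenyl of compound 1 apart from both other aryl groups, with no measured compound going against that among these three. Nothing available here explains this separation.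

Going by these compounds, it remains open whether the amino group is specifically required or whether another group on the same aromatic carbon, such as hydroxyl, methylamino, dimethylamino or acetamido, would give a number close to that of compound 1. The compounds shown also leave open how a carboxylic acid on that carbon, or an aminomethyl group there, would read in this assay, since only three aryl groups on the sulfonyl sulfur carry numbers.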